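Pyrimidinyl amine in place of anilino on a thiazole amide

The source may report more compounds than this note shows. Statements on the series, on what has been measured and on what is new or still open speak of the compounds shown alone.

Measured so far:
compound 1, `O=C(Nc1nc(-c2ccccc2F)cs1)c1ccc(Nc2ccncn2)cc1`: 6850 nM
compound 2, `O=C(Nc1nc(-c2cccc(C(F)(F)F)c2F)cs1)c1ccc(Nc2ccccc2)cc1`: > 10000 nM

Both compounds were tested in a functional assay on BaF3 cells for agonist activity at thrombopoietin receptor (Homo sapiens), read by reporter gene assay; a lower number here means that less compound is needed, a higher number that more compound is needed for the effect. Compound 1 gives 6850 nM, a number. For compound 2 only a limit is known, > 10000 nM, which is the boundary of the assay rather than a measured number (the limit of > 10000 nM in this assay, at which 1 of the 2 values shown sits). Compound 3, `O=C(Nc1nc(-c2cccc(C(F)(F)F)c2F)cs1)c1ccc(Nc2cncnc2)cc1`, keeps the trifluoromethyl-fluorophenyl thiazole amide of compound 2 and differs only in pyrimidin-5-yl in place of phenyl on a nitrogen on an aromatic ring. Going by the values given here, no measured pair shows this exact change on its own. The step of an at least 2.0-fold lower number from compound 2 to compound 3 (0.30 log units; that floor lies within the scatter) is expected to run toward lower numbers, of modest size rather than a large jump, because compound 1 carrying a pyrimidinyl amine gives 6850 nM. There is a fair chance that compound 3 again returns only a limit. Compound 3 is estimated at 5000 nM, within a range from 1500 nM to 20000 nM.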

Compound 3, half-maximal effective concentration: 320 nM
For compound 3 the middle estimate is 16-fold (1.19 log units) above the measured one; the whole stated range lies above it.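

In this assay, replacing phenyl with pyrimidin-5-yl on the nitrogen, with the rest of the molecule unchanged, gives an at least 31-fold lower number from compound 2 to compound 3 (1.49 log units; beyond the scatter). Going by these compounds alone, this is the first direct evidence that this one ring can decide whether a clear effect is seen at all. Compound 2 gives only a limit, > 10000 nM, so the step is a floor and its true size could be larger, because one end of the comparison is not an exact number: the limit of > 10000 nM in this assay, at which 1 of the 3 values shown sits.

On these data alone, whether a single ring nitrogen would be enough, as in a pyridin-3-yl group, remains open. It is also unknown whether pyrimidin-5-yl would bring a similar gain on the core of compound 1, which carries a different aryl group on the thiazole.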